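Two hydroxymethyl groups on one core

A few compounds are considered here, and "the series" means these few. Any claim that something is new, unique, unknown or untested is made for them only; others in the source may bear on it.

Compound 1 `Cc1c(CO)cc2n1[C@@H](c1ccccc1)SC2` and compound 2 `Cc1cc(CO)c2n1[C@@H](c1ccccc1)SC2` share one core and carry a single hydroxymethyl group each. In a functional assay on WiDr cells (Homo sapiens) for cytotoxicity, read by MTT assay, with a stated time of 24 h (a higher number here means a weaker inhibitor, a lower number a stronger inhibitor), compound 1 gives 55500 nM. In this assay compound 2 gives 144000 nM, the highest of the two numbers and beyond the scatter from compound 1. Compound 3 `Cc1c(CO)c(CO)c2n1[C@@H](c1ccccc1)SC2` carries both groups at once; relative to compound 2 the change is hydroxymethyl in place of hydrogen on an aromatic carbon. Going by the values given here, no pair of measured compounds shows this step, so only a modest change toward compound 1 is anticipated. Compound 3 is expected at 90000 nM in this assay, between 40000 nM and 200000 nM. The step of a 1.6-fold lower number from compound 2 to compound 3 (0.20 log units; within the scatter) is thus expected to be small.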

Compound 3, half-maximal inhibitory concentration: 60000 nM
Compound 3: middle estimate off by 1.5-fold (0.18 log units), on the high side; measured number inside the range.
By their numbers in this assay, from the lowest: compounds 1 and 3 (each within the scatter of the next); then compound 2.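

Hydroxymethyl in place of hydrogen on the aromatic carbon next to the ring atom that bears a methyl group gives a 2.4-fold lower number from compound 2 to compound 3 (0.38 log units; beyond the scatter) in this assay, a step beyond the scatter. The same kind of change at the other hydroxymethyl site gives a 1.1-fold higher number from compound 1 to compound 3 (0.03 log units; within the scatter), which lies within the scatter, so a group on this carbon goes with the lower numbers among these three compounds. Nothing available explains this difference between the two steps. From the compounds shown here alone, whether an amine, a carboxylic acid or a longer chain on this carbon would match hydroxymethyl remains open.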